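From Bromo to Chloro in Compound 1

The source may report more compounds than this note shows. Statements on the series, on what has been measured and on what is new or still open speak of the compounds shown alone.

In a functional assay on T98G cells (Homo sapiens) for inhibition, read by MTT assay, with a stated time of 72 h (a higher number here means a weaker inhibitor, a lower number a stronger inhibitor), compound 1 `CC1(C)CC(NC(=S)Nc2cccc(C#N)c2)c2cc(Br)ccc2O1` gives 9000 nM, the second highest of three measured numbers. Compound 2 `CC1(C)CC(NC(=S)Nc2cccc([N+](=O)[O-])c2)c2cc(Br)ccc2O1` gives 4000 nM, and compound 3 `COc1cccc(NC(=S)NC2CC(C)(C)Oc3ccc(Br)cc32)c1` gives 87000 nM. Compound 4 `CC1(C)CC(NC(=S)Nc2cccc(C#N)c2)c2cc(Cl)ccc2O1` differs from compound 1 by one change: chloro in place of bromo on an aromatic carbon. The measured steps only exchange cyano, nitro and methoxy: a modest 2.3-fold lower number from compound 1 to compound 2 (0.35 log units; beyond the scatter), a modest 9.7-fold higher number from compound 1 to compound 3 (0.99 log units; beyond the scatter) and a large 22-fold higher number from compound 2 to compound 3 (1.34 log units; beyond the scatter). None of them tests a change of bromo, so they offer no direct guide. With no such evidence, no change beyond the scatter is expected in this assay, with an estimated 1.1-fold higher number from compound 1 to compound 4 (0.05 log units; within the scatter). Compound 4 is expected at 10000 nM, with an estimated range of 4500 nM to 22000 nM.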

Compound 4, half-maximal inhibitory concentration: 10000 nM
The estimate for compound 4 equals the measured number at the digits printed; the range from low to high includes it.
By their numbers in this assay, from the lowest: compound 2; then compounds 1 and 4 (each within the scatter of the next); then compound 3.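

Chloro in place of bromo gives a 1.1-fold higher number from compound 1 to compound 4 (0.05 log units; within the scatter) in this assay. This is the first step shown at this position on the shared core, as the earlier steps only exchanged cyano, nitro and methoxy elsewhere in the molecule. With the cyano group held fixed, the two halogens cannot be told apart in this read-out, and no supporting data bear on why.

As far as these compounds go, whether fluoro, a methyl group or an amine at this position would give a similar number remains open. So does whether chloro and bromo also match when nitro or methoxy replaces cyano.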